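The source may hold more compounds than are shown below. What is called first, only, known or untested is meant among the compounds shown, and "the series" means these compounds.

Measured compounds:
compound 1, `CCOC(=O)c1c(-c2c(Cl)c3ccccc3oc2=O)nn(-c2cccc(C)c2)c1C(=O)OCC`, 30000 nM
compound 2, `CCOC(=O)c1c(-c2cc3ccccc3oc2=O)nn(-c2cccc(C)c2)c1C(=O)OCC`, 245000 nM
compound 3, `COC(=O)c1c(-c2cc3ccccc3oc2=O)nn(-c2cccc(C)c2)c1C(=O)OC`, 45000 nM

These three share one core, differing in the substituent on the fused ring and in the ester groups. In a functional assay on HeLa cells (Homo sapiens) for cytotoxicity, read by MTT assay, with a stated time of 48 h (a higher number here means a weaker inhibitor, a lower number a stronger inhibitor), compound 1 gives 30000 nM, compound 2 gives 245000 nM and compound 3 gives 45000 nM. Compound 2 therefore stands with the highest number of the three: compound 3 is nearest, with a lower number, and compound 1 furthest, with the lowest. Within the data shown here, the one single-point step among them runs from compound 1 to compound 2, an 8.2-fold higher number from compound 1 to compound 2 (0.91 log units; beyond the scatter), which is the change from chloro to hydrogen on an aromatic carbon.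

The new compound, compound 4, `CCOC(=O)c1c(-c2cc3ccccc3oc2=O)nn(-c2cccc(F)c2)c1C(=O)OCC`, differs from compound 2 in another place: fluoro in place of methyl on an aromatic carbon. Among the measured compounds shown here, no measured step touches the aryl group on the nitrogen, so the chloro-to-hydrogen step an 8.2-fold higher number from compound 1 to compound 2 (0.91 log units; beyond the scatter) does not bear directly on this change, and the pair of compounds 2 and 3 differs in the esters, not here. With nothing to guide it, the expectation is a step no larger than the scatter, a 1.4-fold lower number from compound 2 to compound 4 (0.13 log units; within the scatter). Compound 4 is thus estimated at 180000 nM in this assay, with a range from 60000 nM to 500000 nM.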

Compound 4, half-maximal inhibitory concentration: 68000 nM
The estimate for compound 4 lay 2.6-fold (0.42 log units) above the measured number, within the range that was stated.
By their numbers in this assay, from the lowest: compounds 1, 3 and 4 (each within the scatter of the next, the first and the last beyond it); then compound 2.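

In this assay, among these compounds, the change from 3-methylphenyl to 3-fluorophenyl gives a 3.6-fold lower number from compound 2 to compound 4 (0.56 log units; beyond the scatter) and so shows that the aryl group on the nitrogen, which no earlier step touched, also moves the number; until now the only single-point step was on the fused ring, an 8.2-fold higher number from compound 1 to compound 2 (0.91 log units; beyond the scatter) and likewise beyond the scatter. The exchange is one heavy atom for one heavy atom, with no hydrogen-bond donor or acceptor counted on either side, yet the step still lies beyond the scatter, although this rests on a single pair. Nothing available here accounts for the lower number with fluoro in place of methyl.

The compounds shown cannot tell whether the step belongs to the arrival of fluoro or to the departure of methyl, and a plain hydrogen, a chloro, a methoxy or an amine in the same place on the ring would be needed to separate the two. Also open, as far as these compounds go, is whether the same step would appear on the methyl esters of compound 3 or alongside the chloro group of compound 1.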